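The compounds below may be only part of what the source reports. "The series", "measured", "known", "first", "only" and "open" are said of these compounds alone.

Values in a functional assay on HOS cells (Homo sapiens) for antiproliferative activity, read by sulforhodamine B assay; a higher number here means a weaker inhibitor of growth, a lower number a stronger inhibitor of growth:
- compound 1 `CC[C@@H]1O[C@H](COCc2ccccc2)[C@@H](OCc2ccccc2)[C@H](OCc2ccccc2)[C@H]1O`: 34200 nM
- compound 2 `O[C@@H]1[C@@H](OCc2ccccc2)[C@H](OCc2ccccc2)[C@@H](COCc2ccccc2)O[C@H]1c1ccccc1`: > 50000 nM (a limit)
- compound 3 `CC[C@@H]1O[C@H](COCc2ccccc2)[C@@H](OCc2ccccc2)[C@H](OCc2ccccc2)C1=O`: 4300 nM

Compound 3 at 4300 nM holds the lowest number of the series, and compound 1 at 34200 nM lies above it by more than the scatter. Compound 2 stands at > 50000 nM, which is a limit of the assay and not a number.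

Next is compound 4 `CC(C)C[C@@H]1O[C@H](COCc2ccccc2)[C@@H](OCc2ccccc2)[C@H](OCc2ccccc2)C1=O`. The change from compound 3 is isopropyl in place of methyl on a saturated chain carbon bound to a saturated ring carbon. Cut one bond further out, it reads ethyl to isobutyl.

Among the compounds with values here, only one measured step bears on this, an at least 1.4-fold higher number from compound 1 to compound 2 (0.16 log units; that floor lies within the scatter). There ethyl also leaves, but phenyl enters, and the step was measured on the core of compound 1, not that of compound 3. It is a floor only, so it gives a weak hint at most that a larger group does not lower the number in this assay. A small rise or no change beyond the scatter is therefore expected, and the expected step is a 1.3-fold higher number from compound 3 to compound 4 (0.11 log units; within the scatter).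

The estimated value for compound 4 is 5500 nM, with an expected range of 1800 nM to 18000 nM.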

Compound 4, concentration for 50% growth inhibition: > 50000 nM
Compound 4: only a limit was reported (the forecaster's own chance of this, stated with the estimate: 3%); middle value at least 9.0-fold (0.95 log units) from the limit.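

In this assay, within the data shown here, the saturated chain carbon bound to a saturated ring carbon proves sensitive to change: isopropyl in place of methyl there gives an at least 11-fold higher number from compound 3 to compound 4 (1.06 log units; beyond the scatter), a large step beyond the scatter, whereas the only earlier step, an at least 1.4-fold higher number from compound 1 to compound 2 (0.16 log units; that floor lies within the scatter), gave a floor within the scatter on the core of compound 1. Read one bond further out, ethyl is compatible with a measurable number on this core and isobutyl is not. Compound 4 gives > 50000 nM, which is a limit of the assay, so the step is a floor and its true size stays unread: the limit of > 50000 nM in this assay, at which 2 of the 4 values shown sit.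

The compounds shown leave open whether a straight propyl or butyl chain at this place behaves like ethyl or like isobutyl, and whether an amine or a carboxylic acid on the chain would hold the number of compound 3 at 4300 nM. They also leave open whether isobutyl in place of ethyl gives a step of similar size on the core of compound 1.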